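This account rests on a few compounds, and the source may have more. Where it says the series, first, only, none or still open, it means among the compounds named here.

Going by the values given here, in a functional assay on the whole organism with Mus musculus as the target, in the maximal electroshock model (on this read-out higher numbers stand for an effect only at larger amounts of compound and lower numbers for an effect already at smaller amounts), compound 3 `Cc1nn2cnnc2cc1Cc1ccccc1Cl` gives 6 mg/kg, the lowest of the three numbers known so far. Compound 2 `Cc1nn2cnnc2cc1Cc1ccccc1` stands nearest, giving 9.5 mg/kg. Compound 1 `Cc1nn2cc(-c3ccccc3)nc2cc1Cc1ccccc1` lies furthest away, giving 105 mg/kg. Compound 4 `Cc1nn2cnnc2cc1Cc1c(Cl)cccc1Cl` differs from compound 3 in one place: chloro in place of hydrogen on an aromatic carbon. Among the compounds with values here, only one measured step bears on a chloro entering this ring, the move a 1.6-fold lower number from compound 2 to compound 3 (0.20 log units; within the scatter), which stayed within the scatter. A second chloro on the same ring is therefore expected to leave the number close to where it stands, with a step of a 1.2-fold lower number from compound 3 to compound 4 (0.08 log units; within the scatter) that need not rise above the scatter. Compound 4 is estimated at 5 mg/kg in this assay, with a range from 2.5 mg/kg to 10 mg/kg.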

Compound 4, dose for half-maximal effect: 6.2 mg/kg
Compound 4: the middle estimate sits 1.2-fold (0.09 log units) below what was measured; measured number inside the range.
By their numbers in this assay, from the lowest: compounds 3, 4 and 2 (each within the scatter of the next); then compound 1.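

A second chloro, placed on the aromatic carbon ortho to a large group and meta to a chloro group, gives a 1.0-fold higher number from compound 3 to compound 4 (0.01 log units; within the scatter) in this assay, so this position accepts the added atom without a change beyond the scatter. Together with a 1.6-fold lower number from compound 2 to compound 3 (0.20 log units; within the scatter), this means that neither chloro step on this ring rises above the scatter. Nothing available explains why the number holds steady.

On these data alone, whether an amine or a carboxylic acid at this position would behave like chloro stays open. So does whether chloro would give similar steps on the core of compound 1.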